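A few compounds are considered here, and "the series" means these few. Any claim that something is new, unique, unknown or untested is made for them only; others in the source may bear on it.

Measured so far:
- compound 2 `CS(=O)(=O)c1ccc(C(=O)N2CCC(c3nc4cc(OS(=O)(=O)c5cccc6cnccc56)ccc4[nH]3)CC2)cc1`: 7 nM
- compound 1 `O=C(c1ccc(Oc2ccccc2)cc1)N1CCC(n2cncc2-c2ccc(OS(=O)(=O)c3cccc4cnccc34)cc2)CC1`: 187 nM

In an assay on HEK293 cells for antagonist activity at P2X purinoceptor 7 (Homo sapiens), read by fluorescence, with a stated time of 2 h (a higher number here means a weaker inhibitor, a lower number a stronger inhibitor), compound 2 gives 7 nM. It holds the lowest of the two numbers measured; the nearest, compound 1, gives 187 nM in this assay, a gap that lies beyond the usual scatter. Compound 3 `CN(C)c1ccc(C(=O)N2CCC(c3nc4cc(OS(=O)(=O)c5cccc6cnccc56)ccc4[nH]3)CC2)cc1` has not yet been measured in this assay. It differs from compound 2 in one place: dimethylamino in place of methylsulfonyl on an aromatic carbon. Among the compounds with values here, no step between measured compounds shows what this exchange does, so the size of its effect in this assay is unknown. Compound 3 is expected to come out somewhat weaker than compound 2, a step from compound 2 to compound 3 of a 2.9-fold higher number from compound 2 to compound 3 (0.46 log units; beyond the scatter), with no certainty that it goes beyond the scatter. For compound 3 the estimate in this assay is 20 nM, ranging from 4 nM to 100 nM.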

Compound 3, half-maximal inhibitory concentration: 41 nM
The estimate for compound 3 lay 2.1-fold (0.31 log units) below the measured number; the range from low to high includes it.
By their numbers in this assay, from the lowest: compound 2; then compound 3; then compound 1.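

In this assay, within the data shown here, the exchange of methylsulfonyl for dimethylamino on an aromatic carbon para to a large group gives a 5.9-fold higher number from compound 2 to compound 3 (0.77 log units; beyond the scatter), the first measured step at this position. The position therefore responds to the group it carries, but the change is modest, and compound 3 remains an inhibitor at 41 nM. Nothing measured here explains why the two groups differ in this way.

This single step cannot show whether the difference comes from removing methylsulfonyl or from introducing dimethylamino, and it establishes no trend across groups at this position. The compounds shown also leave open how a nitrile, a carboxylic acid or a primary amine on the same carbon would read in this assay.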